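The source may hold more compounds than are shown below. What is called first, only, known or untested is meant among the compounds shown, and "the series" means these compounds.

Compound 1, with the structure `O=C(/C=C/c1ccc2c(c1)B(O)OC2)c1ccco1`, is the anchor of this account. In an ADME assay on L929 cells (Mus musculus) for cytotoxicity, read by resazurin assay, with a stated time of 72 h (on this read-out higher numbers stand for weaker inhibition and lower numbers for stronger inhibition), compound 1 gives no number but only a limit, > 10 ug/mL. A second compound built on the same core, compound 2, with the structure `COc1cc(C(=O)/C=C/c2ccc3c(c2)B(O)OC3)ccc1[N+](=O)[O-]`, has been measured as well. In this assay compound 2 likewise gives only a limit, > 10 ug/mL. Compound 1 therefore stands at the limit of > 10 ug/mL in this assay, at which 2 of the 2 values shown sit, and the two values shown allow no ordering between the measured compounds, since neither is a number. The unmeasured compound 3, with the structure `O=C(/C=C/c1ccc2c(c1)B(O)OC2)c1cccs1`, differs from compound 1 in one place: thiophen-2-yl in place of furan-2-yl on a carbonyl carbon. For the measured compounds named here, no step between two measured compounds is available, so the size of this change in this assay cannot be read off from the data; the writer expects no shift beyond the usual scatter in either direction, because compound 1 already sits at > 10 ug/mL. Compound 3 is expected in this assay to give 15 ug/mL, with a range from 5 ug/mL to 50 ug/mL. This estimate means a step that the limit leaves unreadable from compound 1 to compound 3, expected to stay within the scatter, and most likely to be reported again only as a limit.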

Compound 3, half-maximal inhibitory concentration: > 10 ug/mL
Compound 3: only a limit was reported (the forecaster's own chance of this, stated with the estimate: 80%); the middle value lies beyond the limit too.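

Compound 1 and compound 3 are both reported only as limits in this assay, and no step can be read for thiophen-2-yl in place of furan-2-yl on a carbonyl carbon. The compounds shown leave open whether this exchange alters cytotoxicity at all and where any of them would give an actual number, as all share one value: the limit of > 10 ug/mL in this assay, at which 3 of the 3 values shown sit.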